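A few compounds are considered here, and "the series" means these few. Any claim that something is new, unique, unknown or untested is made for them only; others in the source may bear on it.

Three compounds of the series have been run in a toxicity assay on the whole organism with Rattus norvegicus as the target, at a dose of 200 mg/kg by the oral route; on this read-out lower numbers stand for a weaker effect and higher numbers for a stronger effect at the one dose given. Compound 1 `Clc1ccc(OCC2=NCCO2)cc1` gives 60%, compound 2 `Brc1ccc(OCC2=NCCO2)cc1` gives 80%, and compound 3 `Fc1ccc(OCC2=NCCO2)cc1` gives 40%. Every step among them is a halogen for a halogen: a number 20 percentage points higher from compound 1 to compound 2 (beyond the scatter), a number 20 percentage points lower from compound 1 to compound 3 (beyond the scatter) and a number 40 percentage points lower from compound 2 to compound 3 (beyond the scatter). Compound 3 thus stands lowest of the three numbers, with compound 1 nearest and compound 2 furthest, both gaps beyond the scatter.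

Compound 4 `O=[N+]([O-])c1ccc(OCC2=NCCO2)cc1` is not yet measured. Its change from compound 3 is nitro in place of fluoro on an aromatic carbon. Among the compounds with values here, no measured step involves a nitro group, so the three halogen steps bear on it only loosely: both steps that end at compound 3 were downward, one modest and one large, and no replacement of the para substituent left the number unchanged. On that basis a rise in this assay is expected rather than a fall, though its size is open. The expected step is a number 20 percentage points higher from compound 3 to compound 4 (beyond the scatter). For compound 4 the estimate is 60%, with a range from 30% to 90%.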

Compound 4, a percentage reported as activity, at one dose (the size of the read-out at that dose, not a potency): 70%
Beside the measured number, compound 4's estimate is 10 percentage points below it; the range from low to high includes it.
By their numbers in this assay, from the lowest: compound 3; then compounds 1, 4 and 2 (each within the scatter of the next, the first and the last beyond it).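

Nitro is the first non-halogen group at this place, and in this assay the replacement gives a number 30 percentage points higher from compound 3 to compound 4 (beyond the scatter) for the change from fluoro, so the read-out here is not confined to the halogen compounds, and compound 3 stays apart from the other three. With three heavy atoms and two hydrogen-bond acceptors, the nitro group still does not separate from the chloro or bromo compounds, giving a number 10 percentage points lower from compound 2 to compound 4 (within the scatter) and a number 10 percentage points higher from compound 1 to compound 4 (within the scatter) in the two comparisons. No supporting measurement accompanies these numbers to explain them.

Open, going by these compounds, is whether another group at this place, such as an amine, a carboxylic acid or a longer chain, would stay with compound 1, compound 2 and compound 4 or fall nearer compound 3. Also open, on these data alone, is how the read-out responds to any change in the shared core, which all four compounds carry unchanged.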